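Swapping fluoro for isopropyl on the pendant phenyl ring

The source may report more compounds than this note shows. Statements on the series, on what has been measured and on what is new or still open speak of the compounds shown alone.

This account follows two compounds that share one core and differ only in the group attached to the urea. Compound 1 `O=C(NCc1ccc(C(F)(F)F)nc1SC1CCCCC1)Nc1cccc2[nH]c(=O)ccc12` carries a pyridine bearing a cyclohexylthio substituent, and in an assay on HEK cells for antagonist activity at transient receptor potential cation channel subfamily V member 1 (Homo sapiens), read by FLIPR (a lower number here means a stronger inhibitor, a higher number a weaker inhibitor), compound 1 gives 2.15 nM. Compound 2 `O=C(NCc1cc(C(F)(F)F)nn1-c1cccc(F)c1)Nc1cccc2[nH]c(=O)ccc12` instead carries a pyrazole joined to a 3-fluorophenyl, and in this assay compound 2 gives 1.28 nM. Of the two numbers, compound 2 has the lower one, but its gap to compound 1 lies within the scatter, so the two values are read as equal.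

Compound 3 `CC(C)c1cccc(-n2nc(C(F)(F)F)cc2CNC(=O)Nc2cccc3[nH]c(=O)ccc23)c1` is the next step. It differs from compound 2 by isopropyl in place of fluoro on an aromatic carbon, that is, 3-fluorophenyl becomes 3-isopropylphenyl. For the measured compounds named here, no measured pair in this set shows such a change, so there is nothing to say how large its effect should be. With both measured compounds sitting close together, the expectation is a step from compound 2 to compound 3 of a 1.3-fold higher number from compound 2 to compound 3 (0.10 log units; within the scatter), within the scatter in either direction. Compound 3 is therefore estimated at 1.6 nM, with a range from 0.4 nM to 6 nM.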

Compound 3, half-maximal inhibitory concentration: 0.88 nM
Compound 3: the middle estimate sits 1.8-fold (0.26 log units) above what was measured, within the range that was stated.
By their numbers in this assay, from the lowest: compounds 3, 2 and 1 (each within the scatter of the next, the first and the last beyond it).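

In this assay, isopropyl in place of fluoro on the aromatic carbon gives a 1.5-fold lower number from compound 2 to compound 3 (0.16 log units; within the scatter) and so lies within the scatter, which means compound 2 and compound 3 read as equal. For the compounds shown here, this is the first pair in the account that differs in one place, and it shows that this carbon of the six-membered aromatic ring, meta to a large group, can carry either a single fluorine or a branched group of three carbons with no change that the assay can resolve; compound 1 has no such phenyl ring and could not show this. Nothing available explains why the two substituents read alike, and this single pair sets no trend for the position.

Fluoro and isopropyl are the only two groups seen at this carbon, so it remains open whether an amine, a carboxylic acid or a longer chain such as n-butyl would leave the number in the same place. From the compounds shown here alone, it is also open whether a ring such as cyclohexyl, larger again than isopropyl, would still read as equal to compound 2 and compound 3.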